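A few compounds are considered here, and "the series" means these few. Any claim that something is new, unique, unknown or untested is made for them only; others in the source may bear on it.

Measured compounds:
compound 1, `CCC1C(=O)N(C)c2cnc(Nc3ccc(S(=O)(=O)NC)cc3)nc2N1c1ccn(C)n1`: 71.6 nM
compound 2, `CCC1C(=O)N(C)c2cnc(-n3ccc4cc(C(=O)NC(C)C)ccc43)nc2N1c1ccn(C)n1`: 125 nM

In an assay for inhibition of serine/threonine-protein kinase PLK2 (Homo sapiens), read by FRET and Z'-LYTE, with a stated time of 1 h (a lower number here means a stronger inhibitor, a higher number a weaker inhibitor), compound 1 gives 71.6 nM and holds the lower of the two numbers; the gap to compound 2 lies within the usual scatter, so the two compounds are not told apart by these data. In this assay compound 2 gives 125 nM.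

Compound 3, `CCCNS(=O)(=O)c1ccc(Nc2ncc3c(n2)N(c2ccn(C)n2)C(CC)C(=O)N3C)cc1`, has not yet been measured. It differs from compound 1 by ethyl in place of hydrogen on a saturated chain carbon bound to a sulfonamide nitrogen, the methylsulfamoyl group becoming propylsulfamoyl. Within the data shown here, no measured pair in this set shows what such a change does, and the two numbers available give no direction to lean on.

The estimated step is a 1.1-fold higher number from compound 1 to compound 3 (0.05 log units; within the scatter), no larger than the scatter, in either direction. Compound 3 is accordingly expected near 80 nM, with a range from 35 nM to 180 nM.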

Compound 3, half-maximal inhibitory concentration: 190 nM
For compound 3 the middle estimate is 2.4-fold (0.38 log units) below the measured one; the whole stated range lies below it.
By their numbers in this assay, from the lowest: compounds 1, 2 and 3 (each within the scatter of the next, the first and the last beyond it).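

Moving from methylsulfamoyl to propylsulfamoyl in this assay gives a 2.7-fold higher number from compound 1 to compound 3 (0.42 log units; beyond the scatter), the first step in the series that can be read from a single change. It shows that this position, on a saturated chain carbon bound to a sulfonamide nitrogen, is not indifferent to ethyl in place of hydrogen: the longer group goes with a weaker inhibitor, although one pair sets no trend. No measured evidence accounts for this step.

From the compounds shown here alone, the shape of the response remains open: an ethyl or butyl chain on the sulfonamide nitrogen would show whether the number rises steadily with chain length. A cyclopropyl group, a terminal hydroxyl or a terminal amine on the propyl chain would show whether the step depends on chain length alone.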